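The source may report more compounds than this note shows. Statements on the series, on what has been measured and on what is new or still open speak of the compounds shown alone.

Compound 1 `O=C(NS(=O)(=O)c1ccc(F)cc1)c1ccc(Nc2nc(NC3(c4ccc(Cl)cc4)CC3)nc(OCC(F)(F)F)n2)cc1`, compound 2 `CC(C)(C)NC(=O)NCCS(=O)(=O)NC(=O)c1ccc(Nc2nc(NC3(c4ccc(Cl)cc4)CC3)nc(OCC(F)(F)F)n2)cc1` and compound 3 `O=C(NS(=O)(=O)CCNC(=O)C1CC1)c1ccc(Nc2nc(NC3(c4ccc(Cl)cc4)CC3)nc(OCC(F)(F)F)n2)cc1` share one core and differ only in the group on the sulfonyl sulfur. In an ADME assay on microsomes from liver (Rattus norvegicus) for metabolic stability, with a stated time of 10 min (on this read-out higher numbers stand for a more stable compound and lower numbers for a less stable compound), compound 1 gives 99%. In this assay compound 2 gives 93%, the lower of the two numbers available, although the step of a number 6 percentage points lower from compound 1 to compound 2 (within the scatter) lies within the scatter. Among the compounds with values here, compound 3 was reported in this assay as "not active" (no number reported), with no number attached, so it contributes no usable step.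

The next compound, compound 4 `CC(=O)NCCS(=O)(=O)NC(=O)c1ccc(Nc2nc(NC3(c4ccc(Cl)cc4)CC3)nc(OCC(F)(F)F)n2)cc1`, differs from compound 2 in one place: methyl in place of (tert-butyl)amino on a carbonyl carbon. Within the data shown here, no measured step touches a carbonyl carbon in this part of the chain, so the only step that bears on the question is the one at the sulfonyl sulfur, which stayed within the scatter. On that basis the change from compound 2 to compound 4 is expected to stay within the scatter as well, with the step of a number 5 percentage points lower from compound 2 to compound 4 (within the scatter) estimated. Compound 4 is therefore expected to give 88% in this assay, in a range from 65% to 100%.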

Compound 4, percent of the compound remaining: 100%
Compound 4: the middle estimate sits 12 percentage points below what was measured, and the stated range covers the measured number.
By their numbers in this assay, from the lowest: compounds 2, 1 and 4 (each within the scatter of the next).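

In this assay, the carbonyl carbon gives its first measured step: methyl in place of (tert-butyl)amino gives a number 7 percentage points higher from compound 2 to compound 4 (within the scatter), so this change, which removes a group of 5 heavy atoms and 1 hydrogen-bond donor, leaves the read-out within the scatter. On the sulfonyl sulfur, 2-acetamidoethyl in place of 4-fluorophenyl gives a number 1 percentage points higher from compound 1 to compound 4 (within the scatter), a second chain at that position that stays within the scatter of the aryl group. Nothing measured here accounts for these results.

Going by these compounds, it remains open whether an amine or a carboxylic acid on that carbonyl carbon, or a chain longer than 2-acetamidoethyl on the sulfonyl sulfur, would also stay within the scatter. Compound 3 has no number in this assay, so its place among these compounds also remains open.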